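Swapping 1-Methylbutoxy for Diethylamino on an Aromatic Carbon

A few compounds are considered here, and "the series" means these few. Any claim that something is new, unique, unknown or untested is made for them only; others in the source may bear on it.

Compound 1 `CCCCOc1ccc(C(=O)/C=C/c2c(/C=C/c3ccc(OC)cc3)cc(OC)cc2OC)cc1`: 5.3 ug/mL in a functional assay on B16-F10 cells (Mus musculus) for antiproliferative activity, read by MTT assay, with a stated time of 48 h; on this read-out higher numbers stand for weaker inhibition and lower numbers for stronger inhibition
Compound 2 `CCCC(C)Oc1ccc(C(=O)/C=C/c2c(/C=C/c3ccc(OC)cc3)cc(OC)cc2OC)cc1`: 6.7 ug/mL
Compound 3 `COc1ccc(/C=C/c2cc(OC)cc(OC)c2/C=C/C(=O)c2ccc(C(F)(F)F)cc2)cc1`: 4.3 ug/mL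

Compound 2 stands highest of these three numbers, yet a 1.3-fold higher number from compound 1 to compound 2 (0.10 log units; within the scatter) and a 1.6-fold lower number from compound 2 to compound 3 (0.19 log units; within the scatter) both fall within the scatter, so no ordering among the three is claimed. Compound 4 `CCN(CC)c1ccc(C(=O)/C=C/c2c(/C=C/c3ccc(OC)cc3)cc(OC)cc2OC)cc1` differs from compound 2 by diethylamino in place of 1-methylbutoxy on an aromatic carbon. For the measured compounds named here, the steps that bear on this change are those at the same aromatic carbon, a 1.2-fold lower number from compound 1 to compound 3 (0.09 log units; within the scatter) and a 1.6-fold lower number from compound 2 to compound 3 (0.19 log units; within the scatter), neither beyond the scatter. Exchanging one group at this carbon for another has so far moved this assay by nothing beyond the scatter, so the expected step of a 1.2-fold lower number from compound 2 to compound 4 (0.09 log units; within the scatter) is likewise none beyond the scatter. Compound 4 is therefore estimated at 5.5 ug/mL, with a range from 2.5 ug/mL to 12 ug/mL.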

Compound 4, half-maximal inhibitory concentration: 8.1 ug/mL
Compound 4: middle estimate off by 1.5-fold (0.17 log units), on the low side; the range from low to high includes it.
By their numbers in this assay, from the lowest: compounds 3, 1, 2 and 4 (each within the scatter of the next).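

With diethylamino at this aromatic carbon, an amine joins the ether and trifluoromethyl groups, and in this assay the number again moves by nothing beyond the scatter, with a 1.2-fold higher number from compound 2 to compound 4 (0.08 log units; within the scatter) and a 1.5-fold higher number from compound 1 to compound 4 (0.18 log units; within the scatter) and a 1.9-fold higher number from compound 3 to compound 4 (0.28 log units; within the scatter) as the steps. All four groups at this carbon therefore give numbers that cannot be told apart in this assay. No measurement shown here accounts for this result.

The compounds shown leave open whether a carboxylic acid, a hydroxyl or a morpholine ring at this carbon would move the number beyond the scatter.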